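Bromo for methyl on the core of compound 2

The source may report more compounds than this note shows. Statements on the series, on what has been measured and on what is new or still open speak of the compounds shown alone.

Compound 2, `COC(=O)[C@@]1(C)CCC=C2[C@@H]1CC[C@@H](C)[C@]2(C)Cc1c(C)[nH]c2ccc(C)cc12`, gives 17000 nM in a functional assay on HeLa cells (Homo sapiens) for inhibition, read by sulforhodamine B assay, with a stated time of 48 h (on this read-out lower numbers stand for stronger inhibition of growth and higher numbers for weaker inhibition of growth), the higher of the two numbers recorded. Compound 1, `COC(=O)[C@@]1(C)CCC=C2[C@@H]1CC[C@@H](C)[C@]2(C)Cc1c[nH]c2ccc(Br)cc12`, gives 10000 nM in this assay, and the gap between compound 1 and compound 2 lies within the scatter. Compound 3, `COC(=O)[C@@]1(C)CCC=C2[C@@H]1CC[C@@H](C)[C@]2(C)Cc1c(C)[nH]c2ccc(Br)cc12`, differs from compound 2 by bromo in place of methyl on an aromatic carbon. Compound 1 also carries bromo at that position, so compound 3 is expected to land near both measured numbers, with the step of a 1.5-fold lower number from compound 2 to compound 3 (0.19 log units; within the scatter) expected to stay within the scatter. In this assay compound 3 is estimated at 11000 nM, within a range of 5000 nM to 25000 nM.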

Compound 3, concentration for 50% growth inhibition: 11000 nM
Compound 3: middle estimate and measured number agree at the digits printed; measured number inside the range.
By their numbers in this assay, from the lowest: compounds 1, 3 and 2 (each within the scatter of the next).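

Compound 3 ties the two earlier compounds together through single changes, which they could not do alone. In this assay, bromo in place of methyl on an aromatic carbon (a 1.5-fold lower number from compound 2 to compound 3 (0.19 log units; within the scatter)) and methyl in place of hydrogen on an aromatic carbon (a 1.1-fold higher number from compound 1 to compound 3 (0.04 log units; within the scatter)) both stay within the scatter, so neither change separates these compounds on this read-out. Nothing available explains this result. The compounds shown leave open whether an amine or a carboxylic acid in place of bromo on this aromatic carbon would give a number beyond the scatter.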